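Amide nitrogen substituent series: heteroaryl exchange

A few compounds are considered here, and "the series" means these few. Any claim that something is new, unique, unknown or untested is made for them only; others in the source may bear on it.

Working notes. The compounds share the core of compound 1 `CC(C)[C@H](C(=O)NC(C)(C)C)c1ccc(Cl)cc1` and differ only in the group on the amide-type nitrogen. In a functional assay on CHO cells for agonist activity at Free fatty acid receptor 2 (Homo sapiens), read by cAMP accumulation (on this read-out higher numbers stand for weaker inhibition and lower numbers for stronger inhibition), compound 1 gives no number, only a limit of the assay, > 100000 nM. Compound 2 `CC(C)[C@H](C(=O)Nc1ccccn1)c1ccc(Cl)cc1` carries pyridin-2-yl on that nitrogen, and in this assay compound 2 gives 1400 nM, the only number shown in the series; the one other value is the limit of > 100000 nM in this assay, at which 1 of the 2 values shown sits. The measured step is an at least 71-fold lower number from compound 1 to compound 2 (1.85 log units; beyond the scatter).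

Compound 3 `CC(C)[C@H](C(=O)Nc1nncs1)c1ccc(Cl)cc1` differs from compound 2 by 1,3,4-thiadiazol-2-yl in place of pyridin-2-yl on an amide-type nitrogen. For the measured compounds named here, the single measured step replaces tert-butyl with an aromatic ring, whereas here one aromatic ring takes the place of another; no measured step covers such an exchange, so the size of the measured step does not transfer to this one. With both compound 2 and compound 3 bearing a nitrogen-containing aromatic ring on the amide-type nitrogen, the change is expected to stay within the scatter, a 1.1-fold higher number from compound 2 to compound 3 (0.03 log units; within the scatter). Compound 3 is therefore estimated at 1500 nM, with a range from 400 nM to 6000 nM.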

Compound 3, half-maximal inhibitory concentration: 12000 nM
Beside the measured number, compound 3's estimate is 8.0-fold (0.90 log units) below it; the whole stated range lies below it.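

Exchanging one aromatic ring for another on the amide-type nitrogen is not neutral in this assay: 1,3,4-thiadiazol-2-yl in place of pyridin-2-yl gives an 8.6-fold higher number from compound 2 to compound 3 (0.93 log units; beyond the scatter), so this position distinguishes between two nitrogen-containing aromatic rings, which the earlier pair could not show. The advantage over tert-butyl is also not confined to pyridin-2-yl, since the five-membered ring still gives a measured number in this assay, with an at least 8.3-fold lower number from compound 1 to compound 3 (0.92 log units; beyond the scatter). Compound 1 stands at a limit of the assay, so this last step is a bound only: the limit of > 100000 nM in this assay, at which 1 of the 3 values shown sits.

Pyridin-2-yl and 1,3,4-thiadiazol-2-yl differ at once in ring size, in the number of hetero atoms and in the presence of sulfur, so the compounds shown cannot separate these changes or give a cause for the step between them. Also open, on these data alone, is how a plain phenyl ring, a thiazol-2-yl ring or a saturated cyclohexyl ring would stand on the same nitrogen, which would show whether the ring nitrogen, the sulfur or the aromatic ring itself carries the difference.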